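Chloro on the benzylamide of compound 1: working notes

The compounds below may be only part of what the source reports. "The series", "measured", "known", "first", "only" and "open" are said of these compounds alone.

Measured so far:
compound 1 `COc1c(C(=O)NCc2ccccc2)c(C)nn1-c1ccccc1` — 23.6 ug/mL
compound 2 `COCc1ccccc1-c1c(C)nn(-c2ccccc2)c1OC` — 20.1 ug/mL

Both numbers come from a physicochemical assay, read by spectrophotometry, with a stated time of 30 min; a higher number here means a weaker inhibitor, a lower number a stronger inhibitor. Compound 1 gives 23.6 ug/mL in this assay, and compound 2 gives 20.1 ug/mL. Compound 1 holds the higher of the two numbers, but its gap to compound 2 lies within the scatter, so the two cannot be told apart. Among the compounds with values here, no step between measured compounds can be drawn, since compound 1 and compound 2 differ in more than one place.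

Compound 3 `COc1c(C(=O)NCc2ccc(Cl)cc2)c(C)nn1-c1ccccc1` has not been measured. It differs from compound 1 in one place: chloro in place of hydrogen on an aromatic carbon. Nothing measured here bears on this change, so the expectation rests on compound 1 alone and is held loose. Compound 3 is expected to come in at 21 ug/mL in this assay, within a range from 10 ug/mL to 45 ug/mL. The expected step is a 1.1-fold lower number from compound 1 to compound 3 (0.05 log units; within the scatter), that is, no change beyond the scatter in either direction.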

Compound 3, half-maximal inhibitory concentration: 16.1 ug/mL
For compound 3 the middle estimate is 1.3-fold (0.12 log units) above the measured one; the measured number falls inside the stated range.
By their numbers in this assay, from the lowest: compounds 3, 2 and 1 (each within the scatter of the next).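

In this assay, the benzylamide of compound 1 gives the series its first step in one place: 4-chlorobenzyl in place of benzyl, with chloro para to a large group, gives a 1.5-fold lower number from compound 1 to compound 3 (0.17 log units; within the scatter), so this position accepts a single chlorine atom without a change that can be told from the scatter. The earlier compounds shown here could not show this, as compound 1 and compound 2 differ in more than one place and offered no reading of any single position. No measurement here accounts for the size of this step or for its direction.

A single substituent leaves open whether this position responds to anything at all in this assay. Groups such as methoxy, an amine or a carboxylic acid at the same place, or chloro elsewhere on the same ring, could settle whether the position stays this flat.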